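Lengthening the hydroxycarbamoyl chain of compound 3

A few compounds are considered here, and "the series" means these few. Any claim that something is new, unique, unknown or untested is made for them only; others in the source may bear on it.

Measured so far in a functional assay on NCI-H1975 cells (Homo sapiens) for antiproliferative activity, read by MTT assay, with a stated time of 72 h (a higher number here means a weaker inhibitor, a lower number a stronger inhibitor), are these compounds:
- compound 1 `C=CC(=O)Nc1cc2c(Nc3ccc(OCc4cccc(F)c4)c(Cl)c3)ncnc2cc1OCc1cn(CCCC(=O)NO)nn1` gives 12000 nM
- compound 2 `C=CC(=O)Nc1cc2c(Nc3ccc(OCc4cccc(F)c4)c(Cl)c3)ncnc2cc1OCc1cn(CCCCC(=O)NO)nn1` gives 14500 nM
- compound 3 `C=CC(=O)Nc1cc2c(Nc3ccc(F)c(Cl)c3)ncnc2cc1OCc1cn(CCC(=O)NO)nn1` gives 4450 nM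

Compound 3 has the lowest of the three numbers, and its gaps to compound 1 and compound 2 lie beyond the scatter. Compound 4 `C=CC(=O)Nc1cc2c(Nc3ccc(F)c(Cl)c3)ncnc2cc1OCc1cn(CCCC(=O)NO)nn1` differs from it by (hydroxycarbamoyl)methyl in place of hydroxycarbamoyl on a saturated chain carbon, two bonds along the chain from an aromatic nitrogen with (hydroxycarbamoyl)methyl in place of hydroxycarbamoyl on a saturated chain carbon, two bonds along the chain from an aromatic nitrogen. Going by the values given here, the one measured step that bears on this is the same change made three bonds along the chain on the core of compound 1. That step is a 1.2-fold higher number from compound 1 to compound 2 (0.08 log units; within the scatter) and it stays within the scatter. No step beyond the scatter is therefore expected in this assay and the estimated step is a 1.1-fold higher number from compound 3 to compound 4 (0.05 log units; within the scatter) in all. For compound 4 the expected value is 5000 nM with an estimated range of 2400 nM to 11000 nM as its likely span.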

Compound 4, half-maximal inhibitory concentration: 1820 nM
For compound 4 the middle estimate is 2.7-fold (0.44 log units) above the measured one; the whole stated range lies above it.
By their numbers in this assay, from the lowest: compound 4; then compound 3; then compounds 1 and 2 (each within the scatter of the next).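

On the fluoro core, the same lengthening of the chain in this assay gives a 2.4-fold lower number from compound 3 to compound 4 (0.39 log units; beyond the scatter), so this position responds to the change there. Fluoro in place of (3-fluorobenzyl)oxy at the same chain length gives a 6.6-fold lower number from compound 1 to compound 4 (0.82 log units; beyond the scatter). The size of the chain step therefore depends on the core that carries it: the same change on two cores in this assay, a 1.2-fold higher number (0.08 log units; within the scatter) from compound 1 to compound 2 and a 2.4-fold lower number (0.39 log units; beyond the scatter) from compound 3 to compound 4, 3.0-fold (0.47 log units) apart, beyond the scatter of two such steps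

The compounds shown leave open whether a longer chain than the 3-(hydroxycarbamoyl)propyl group would lower the number further on the core of compound 4. They also leave open whether a carboxylic acid could replace the hydroxycarbamoyl end.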